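This account rests on a few compounds, and the source may have more. Where it says the series, first, only, none or still open, it means among the compounds named here.

Compound 1 `O=C(Nc1cc(C(F)(F)F)cc(C(F)(F)F)c1)c1cnc(C(F)(F)F)nc1Cl` gives > 10000 nM in an assay on Jurkat cells for activation of nuclear factor NF-kappa-B complex (Homo sapiens); a lower number here means a stronger inhibitor, a higher number a weaker inhibitor.
Compound 2 `O=C(Nc1cc(C(F)(F)F)cc(C(F)(F)F)c1)c1cnc(-c2ccccc2)nc1` gives > 10000 nM in this assay.

Compound 2 stands at a limit of this assay, not at a measured number, and this limit does not say how weak it truly is. The same holds for compound 1 in its own sentence: its value is also a limit. Together they show the picture of the limit of > 10000 nM in this assay, at which 2 of the 2 values shown sit, with both measured compounds sitting at that boundary rather than at a number inside the range of this assay.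

Compound 3 `O=C(Nc1cc(C(F)(F)F)cc(C(F)(F)F)c1)c1cnc(C(F)(F)F)nc1` has not yet been measured. Compared with compound 2 the change is trifluoromethyl in place of phenyl on an aromatic carbon. Among the compounds with values here, no measured pair in this set shows how this kind of swap acts, so there is no measured step to lean on. Given that both compounds share the same amide and the same core, and that compound 2 already sits at the limit, the expectation for the step from compound 2 to compound 3 is a step that the limit leaves unreadable from compound 2 to compound 3, that is, no change beyond the scatter in either direction. For compound 3 the estimated value in this assay is therefore 12000 nM, with a range from 3000 nM to 50000 nM.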

Compound 3, half-maximal inhibitory concentration: > 10000 nM
Compound 3: only a limit was reported; the forecaster's own chance of this, stated with the estimate: 75%; the middle value lies beyond the limit too.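

In this assay compound 3 gives > 10000 nM, which is a limit and not a number. Within the data shown here, no step to compound 3 can be read from compound 1 or compound 2, and the picture stays as follows: the limit of > 10000 nM in this assay, at which 3 of the 3 values shown sit. The compounds shown leave open how weak each one truly is, and which change to the shared core would give a measured number.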